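The compounds below may be only part of what the source reports. "The series", "measured", "known", "first", "only" and "open" are said of these compounds alone.

Series notes. Compound 1 `CC(=O)N1CCN(CC(=O)N2CCN(c3cc4c(cc3F)c(=O)c(C(=O)O)cn4C3CC3)CC2)CC1` carries an acetyl on an amine nitrogen in a ring; in an ADME assay on RAW264.7 cells (Mus musculus) for cytotoxicity, read by MTT assay, with a stated time of 72 h (on this read-out higher numbers stand for weaker inhibition and lower numbers for stronger inhibition), compound 1 gives 154000 nM. Compound 2 `Cc1cccc(N2CCN(CC(=O)N3CCN(c4cc5c(cc4F)c(=O)c(C(=O)O)cn5C4CC4)CC3)CC2)c1` gives 154000 nM in this assay, and compound 3 `CCN1CCN(CC(=O)N2CCN(c3cc4c(cc3F)c(=O)c(C(=O)O)cn4C3CC3)CC2)CC1` gives 188000 nM in this assay. Compound 1 stands level with compound 2, the two together being the lowest of the three numbers, with compound 3 the furthest away. The steps measured so far: no change at the digits printed from compound 1 to compound 2 (within the scatter); a 1.2-fold higher number from compound 1 to compound 3 (0.09 log units; within the scatter); a 1.2-fold higher number from compound 2 to compound 3 (0.09 log units; within the scatter). Every one of them falls within the scatter, so the group on this ring nitrogen has so far not moved the number at all.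

Compound 4 `O=C(O)c1cn(C2CC2)c2cc(N3CCN(C(=O)CN4CCN(c5ncccn5)CC4)CC3)c(F)cc2c1=O` is still to be measured. It differs from compound 1 in one place: pyrimidin-2-yl in place of acetyl on an amine nitrogen in a ring. The three measured steps all swap the group on this same ring nitrogen, acetyl to 3-methylphenyl, acetyl to ethyl and 3-methylphenyl to ethyl, and none of them reached beyond the scatter. The change to compound 4 is of the same kind, so no step beyond the scatter is expected in this assay in either direction. For compound 4 the expected step is a 1.0-fold higher number from compound 1 to compound 4 (0.02 log units; within the scatter). The estimate for compound 4 in this assay is 160000 nM, with a range from 80000 nM to 320000 nM.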

Compound 4, half-maximal inhibitory concentration: 227000 nM
For compound 4 the middle estimate is 1.4-fold (0.15 log units) below the measured one, within the range that was stated.
By their numbers in this assay, from the lowest: compounds 1, 2, 3 and 4 (each within the scatter of the next).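

Pyrimidin-2-yl on this ring nitrogen extends the tolerated set to an aromatic ring with two hetero atoms, and in this assay its steps stay within the scatter against all three earlier groups (a 1.5-fold higher number from compound 1 to compound 4 (0.17 log units; within the scatter); a 1.5-fold higher number from compound 2 to compound 4 (0.17 log units; within the scatter); a 1.2-fold higher number from compound 3 to compound 4 (0.08 log units; within the scatter)). Acetyl, ethyl, 3-methylphenyl and pyrimidin-2-yl therefore cannot be separated by this read-out, even though the change from acetyl to pyrimidin-2-yl brings a ring and more heavy atoms onto the position and exchanges the carbonyl for ring nitrogens. No available measurement bears on why the number stays flat across these four groups.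

Still open, from the compounds shown here alone, is whether a carboxylic acid or a primary amine at the end of a longer chain on this ring nitrogen would give a step beyond the scatter. The response to changes elsewhere is open too, as all four compounds share the same core and the same carbonyl-bearing link to the second ring.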